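Aryl urea series: expectation for compound 4

This account rests on a few compounds, and the source may have more. Where it says the series, first, only, none or still open, it means among the compounds named here.

Measured so far:
compound 1 `COc1cc(NC(=O)Nc2cc(Nc3ccc(C)c(C)c3)ncn2)cc(OC)c1`: 66%
compound 2 `COc1cc(NC(=O)Nc2cc(Nc3ccc(F)c(Cl)c3)ncn2)cc(OC)c1`: 77.5%
compound 3 `COc1cc(NC(=O)Nc2cc(Nc3ccc(Br)cc3OC)ncn2)cc(OC)c1`: 83%

All three share one core and differ only in the aryl group on a nitrogen on an aromatic ring. In a functional assay on PC-9 cells (Homo sapiens) for inhibition, read by MTT assay, with a stated time of 48 h, tested at 10 uM (on this read-out higher numbers stand for more inhibition at the one concentration tested (going by the name of the read-out) and lower numbers for less inhibition), compound 3 gives the highest of the three numbers. The gap to compound 1 is beyond the scatter, a number 17 percentage points higher from compound 1 to compound 3 (beyond the scatter); the gap to compound 2 is within it, a number 5.5 percentage points higher from compound 2 to compound 3 (within the scatter), so compound 3 and compound 2 cannot be ranked against each other on this assay.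

Compound 4 `COc1cc(NC(=O)Nc2cc(Nc3cc(C)cc(F)c3)ncn2)cc(OC)c1` is not yet measured. Its change from compound 3 reads (3-fluoro-5-methylphenyl in place of 4-bromo-2-methoxyphenyl on a nitrogen on an aromatic ring). Going by the values given here, the steps that bear on this position are a number 11.5 percentage points higher from compound 1 to compound 2 (beyond the scatter) and a number 17 percentage points higher from compound 1 to compound 3 (beyond the scatter), both modest and both upward from the compound 1 substituent; the step of a number 5.5 percentage points higher from compound 2 to compound 3 (within the scatter) lies within the scatter. The entering group carries one methyl and one fluorine, features resembling compound 1 and compound 2 in part, so a small downward step from compound 3 is expected, a number 11 percentage points lower from compound 3 to compound 4 (beyond the scatter), probably within the scatter. Compound 4 is estimated at 72% with a range of 58% to 86% in this assay.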

Compound 4, a percentage reported as inhibition, at one concentration (the size of the read-out at that concentration, not a potency): 64.5%
The estimate for compound 4 lay 7.5 percentage points above the measured number; measured number inside the range.
By their numbers in this assay, from the lowest: compounds 4 and 1 (each within the scatter of the next); then compounds 2 and 3 (each within the scatter of the next).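

In this assay, the 3-fluoro-5-methylphenyl group falls clearly short of the two best aryl groups on this nitrogen, with a number 18.5 percentage points lower from compound 3 to compound 4 (beyond the scatter) and a number 13 percentage points lower from compound 2 to compound 4 (beyond the scatter), while a number 1.5 percentage points lower from compound 1 to compound 4 (within the scatter) leaves compound 4 and compound 1 unranked against each other. The four aryl groups therefore form two levels, compounds 1 and 4 in one and compounds 2 and 3 in the other; both members of the lower level carry a ring methyl, whereas fluorine appears at both levels, in compound 2 as well as compound 4. No measured evidence bears on why these levels separate.

Still open, from the compounds shown here alone, is whether the bromine or the methoxy of compound 3 alone would hold its level, as the two occur only together here. Equally open, going by these compounds, is how an aryl group bearing an amine or a carboxylic acid would read at this position.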